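The source may report more compounds than this note shows. Statements on the series, on what has been measured and on what is new or still open speak of the compounds shown alone.

Compound 1 `COc1ccc(NC(=O)OC(CCN(C)C)c2ccc(Cl)cc2)cc1`: 170%
Compound 2 `CN(C)CCC(OC(=O)Nc1ccc(C(F)(F)F)cc1)c1ccc(Cl)cc1`: 94%
Compound 3 `CN(C)CCC(OC(=O)Nc1ccc(-c2ccccc2)cc1)c1ccc(Cl)cc1`: 58%

In an assay on NIH3T3 cells with Urotensin-2 receptor (Homo sapiens) as the target (a lower number here means a smaller maximal response, a higher number a larger maximal response), compound 3 stands lowest of the three numbers, with the steps of a number 112 percentage points lower from compound 1 to compound 3 (beyond the scatter) and a number 36 percentage points lower from compound 2 to compound 3 (beyond the scatter) both beyond the scatter. Compound 4 `CN(C)CCC(OC(=O)Nc1ccc(Oc2ccccc2)cc1)c1ccc(Cl)cc1` differs from compound 3 in one place: phenoxy in place of phenyl on an aromatic carbon. The two steps that bear on this position, a number 112 percentage points lower from compound 1 to compound 3 (beyond the scatter) and a number 36 percentage points lower from compound 2 to compound 3 (beyond the scatter), were large, and each exchanged a smaller group for a larger one. The change from phenyl to phenoxy is of a different kind, one ring for another, so no step beyond the scatter is expected, and the estimated step is a number 2 percentage points higher from compound 3 to compound 4 (within the scatter). Compound 4 is therefore estimated at 60%, with a range from 35% to 95%.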

Compound 4, largest response reached (reported as efficacy), in percent of the reference or control that the assay uses: 107%
Estimate against measurement, compound 4: 47 percentage points below; the whole stated range lies below it.
By their numbers in this assay, from the lowest: compound 3; then compound 2; then compound 4; then compound 1.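

In this assay, the two ring-bearing groups do not behave alike: phenoxy in place of phenyl gives a number 49 percentage points higher from compound 3 to compound 4 (beyond the scatter), so the order at this position does not simply follow group size. The earlier fall with larger groups does not hold for compound 4, which gives a number 13 percentage points higher from compound 2 to compound 4 (beyond the scatter), although the methoxy compound remains higher, with a number 63 percentage points lower from compound 1 to compound 4 (beyond the scatter) as the step. No measurement at hand accounts for this result. From the compounds shown here alone, it remains open whether the oxygen link is what matters. A benzyl group or a phenylamino group at this position could separate the link from the ring.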